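The source may report more compounds than this note shows. Statements on the series, on what has been measured and on what is new or still open speak of the compounds shown alone.

Measured compounds:
- compound 1 `Oc1cccc(-c2cc(-c3ccncc3)nc(-c3cccc(Cl)c3)c2)c1`: "not determined" (no result reported)
- compound 2 `Oc1ccc(-c2cc(-c3cccc(Cl)c3)nc(-c3cccs3)c2)cc1`: 5740 nM
- compound 3 `Oc1cccc(-c2cc(-c3ccsc3)nc(-c3cccc(Cl)c3)c2)c1`: 3330 nM

Three compounds sharing a core were examined in a functional assay on DU-145 cells (Homo sapiens) for cytotoxicity, read by CCK-8 assay and cell counting, with a stated time of 2 days; a higher number here means a weaker inhibitor, a lower number a stronger inhibitor. For compound 1 the entry reads "not determined" (no result reported), so no number was obtained. In this assay compound 2 gives 5740 nM, and compound 3 gives 3330 nM. These two numbers lie within the usual scatter of each other, so compound 3 cannot be set apart from compound 2 on the data at hand; it is simply one of two compounds with a determined value.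

Compound 4 `Oc1cccc(-c2cc(-c3cccc(Cl)c3)nc(-c3cccs3)c2)c1` is reached from compound 3 by thiophen-2-yl in place of thiophen-3-yl on an aromatic carbon. Going by the values given here, no pair of measured compounds shows this change, so its size can only be guessed; the change rearranges the same atoms without adding or removing any. He expects a small step, plausibly no larger than the scatter, in either direction: a 1.1-fold lower number from compound 3 to compound 4 (0.05 log units; within the scatter). For compound 4 he estimates 3000 nM in this assay, with a range from 1200 nM to 8000 nM.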

Compound 4, half-maximal inhibitory concentration: 2650 nM
Compound 4: the middle estimate sits 1.1-fold (0.05 log units) above what was measured; measured number inside the range.
By their numbers in this assay, from the lowest: compounds 4, 3 and 2 (each within the scatter of the next, the first and the last beyond it).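

In this assay, thiophen-2-yl in place of thiophen-3-yl next to the ring nitrogen gives a step within the scatter (a 1.3-fold lower number from compound 3 to compound 4 (0.10 log units; within the scatter)), so the data do not separate these two thiophene attachments at this position. Going by these compounds alone, the change from 4-hydroxyphenyl to 3-hydroxyphenyl, by contrast, gives the only step here beyond the scatter, and a modest one (a 2.2-fold lower number from compound 2 to compound 4 (0.34 log units; beyond the scatter)). Nothing measured here accounts for either step.

Compound 1, entered as "not determined" (no result reported), offers no comparison, so these compounds give no number for a group other than a thiophene at this position. They also leave open how a carboxylic acid or an amine on the phenyl ring in place of the hydroxyl would read in this assay.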